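The source may hold more compounds than are shown below. What is called first, only, known or untested is meant among the compounds shown, and "the series" means these compounds.

Working notes on the series. Among the measured compounds shown here, in a functional assay on HepG2 cells (Homo sapiens), read by MTT assay, with a stated time of 48 h (a lower number here means a stronger inhibitor, a higher number a weaker inhibitor), compound 1 (`CCn1c(C(=O)NCCCN(C)C)ccc1C(CC)(CC)c1ccc(OCC(=O)C(C)(C)C)c(C)c1`) gives 960 nM and compound 2 (`CCn1c(C(=O)NCCCN(C)C)ccc1C(CC)(CC)c1ccc(OCC(O)C(C)(C)C)c(C)c1`) gives 360 nM, the lower of the two numbers so far. Compound 3 (`CCn1c(C(=O)NCC(OC)OC)ccc1C(CC)(CC)c1ccc(OCC(O)C(C)(C)C)c(C)c1`) keeps everything in compound 2 except the amide side chain: dimethoxymethyl in place of 2-(dimethylamino)ethyl on a saturated chain carbon bound to an amide-type nitrogen. In words, dimethoxymethyl stands in place of 2-(dimethylamino)ethyl on a saturated chain carbon bound to an amide-type nitrogen. For the measured compounds named here, the only measured step, a 2.7-fold lower number from compound 1 to compound 2 (0.43 log units; beyond the scatter), is modest and sits elsewhere, on a saturated chain carbon bound to an oxygen on an aromatic ring. It therefore serves only as a rough size guide. As far as these compounds go, both measured compounds carry the 3-(dimethylamino)propyl chain, so the effect of replacing it remains untested. In this assay the expected change is a rise, an estimated 4.2-fold higher number from compound 2 to compound 3 (0.62 log units; beyond the scatter) and somewhat larger than that modest step. The estimate for compound 3 is 1500 nM with an expected range of 400 nM to 6000 nM overall.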

Compound 3, half-maximal inhibitory concentration: 23200 nM
Compound 3: the middle estimate sits 15-fold (1.19 log units) below what was measured; measured number outside the range, above it.
By their numbers in this assay, from the lowest: compound 2; then compound 1; then compound 3.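

In this assay, the amide side chain proves a far more sensitive place than the earlier pair could show: dimethoxymethyl in place of 2-(dimethylamino)ethyl gives a 64-fold higher number from compound 2 to compound 3 (1.81 log units; beyond the scatter), a large step beside the modest 2.7-fold lower number from compound 1 to compound 2 (0.43 log units; beyond the scatter). The two groups match in heavy-atom count and neither holds a ring, so the large rise comes with an exchange of nitrogen for oxygen and no change in that count. No measurement here accounts for the size of this step.

As far as these compounds go, whether the rise follows the loss of the dimethylamino group or the arrival of the dimethoxy group stays open, as this single exchange changes both at once. A primary amine, a carboxylic acid or a longer chain ending in dimethylamino on the same carbon would help separate these readings.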